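The source may report more compounds than this note shows. Statements on the series, on what has been measured and on what is new or still open speak of the compounds shown alone.

Compound 1 `CCCOc1ccc(C[C@@H](Cc2ccccc2)C(=O)O)cc1CNC(=O)c1ccc(-c2cccc(F)c2)cc1` returns only a limit in a physicochemical assay for solubility, read by HPLC, in phosphate buffer, measured as thermodynamic solubility, with a stated time of 48 h, at pH 7.2 (a lower number here means a less soluble compound, a higher number a more soluble compound), namely < 1 ug/mL, sitting at the limit of < 1 ug/mL in this assay, at which 1 of the 2 values shown sits. Within the data shown here, compound 2 `CCCOc1ccc(C[C@@H](Cc2ccccc2)C(=O)O)cc1CNC(=O)c1ccc(-c2ccncc2)cc1` gives 34.1 ug/mL in this assay, the single real number in the set. The measured step of an at least 34-fold higher number from compound 1 to compound 2 (1.53 log units; beyond the scatter) was large. Compound 3 `CCCOc1ccc(C[C@@H](Cc2ccccc2)C(=O)O)cc1CNC(=O)c1ccc(-c2cnccn2)cc1` carries the change (pyrazin-2-yl in place of pyridin-4-yl on an aromatic carbon). Among the measured compounds shown here, only that one measured step bears on it, and it ran toward a higher number, so a further rise beyond the scatter is expected though far from certain. The expected step is a 1.8-fold higher number from compound 2 to compound 3 (0.25 log units; within the scatter). Compound 3 is estimated at 60 ug/mL, ranging from 20 ug/mL to 180 ug/mL.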

Compound 3, solubility: 32.2 ug/mL
Estimate against measurement, compound 3: 1.9-fold (0.27 log units) above; measured number inside the range.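

At this position, on an aromatic carbon para to a large group, pyrazin-2-yl and pyridin-4-yl cannot be told apart in this assay: a 1.1-fold lower number from compound 2 to compound 3 (0.02 log units; within the scatter). The large rise seen with pyridin-4-yl is therefore not unique to that ring, as replacing 3-fluorophenyl with pyrazin-2-yl gives an at least 32-fold higher number from compound 1 to compound 3 (1.50 log units; beyond the scatter). That step starts from compound 1, whose value is a limit and not a number: the limit of < 1 ug/mL in this assay, at which 1 of the 3 values shown sits.

Left open is whether the place of the ring nitrogen matters, as pyridin-3-yl would test. Also open, going by these compounds, is how plain phenyl or a saturated amine such as piperidin-4-yl would read at this position in this assay.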